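Dihydropyridine esters: aryl swap at the saturated ring carbon

This account rests on a few compounds, and the source may have more. Where it says the series, first, only, none or still open, it means among the compounds named here.

Measured so far:
compound 1, `CC1=C(C(=O)OC2CCCCC2)C(c2cccc(C#N)c2)C2=C(CC(C)(C)CC2=O)N1`, 43200 nM;
compound 2, `CC1=C(C(=O)OCC2CCN(C(=O)OC(C)(C)C)CC2)C(c2cccc([N+](=O)[O-])c2)C2=C(CC(C)(C)CC2=O)N1`, > 10000 nM.

Both compounds share one core and differ in the ester and the aryl group on the saturated ring carbon. In an assay on HEK293 cells for inhibition of neurogenic locus notch homolog protein 1 (Homo sapiens), read by a luciferase reporter and resazurin assay, with a stated time of 16 h (on this read-out higher numbers stand for weaker inhibition and lower numbers for stronger inhibition), compound 1 gives 43200 nM, a weak result. For compound 2 the read-out in this assay is only a limit, > 10000 nM, not a number; where compound 2 stands is therefore known only from the limit of > 10000 nM in this assay, at which 1 of the 2 values shown sits. Going by the values given here, no step between the two measured compounds can be computed, as they differ in more than one place.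

Compound 3, `CC1=C(C(=O)OCC2CCN(C(=O)OC(C)(C)C)CC2)C(c2cc(Cl)cc(Cl)c2)C2=C(CC(C)(C)CC2=O)N1`, is not yet measured. It keeps the ester of compound 2 and carries 3,5-dichlorophenyl in place of 3-nitrophenyl on a saturated ring carbon. With compound 2 sitting at a limit and compound 1 also weak, the expected step from compound 2 to compound 3 in this assay is a step that the limit leaves unreadable from compound 2 to compound 3, that is, nothing resolvable beyond the scatter. Compound 3 is expected to give about 20000 nM in this assay, with a range from 5000 nM to 80000 nM, and a fair chance that only a limit is reported.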

Compound 3, half-maximal inhibitory concentration: 640 nM
Compound 3: the middle estimate sits 31-fold (1.49 log units) above what was measured; the measured number lies below the stated range.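

In this assay the aryl group on the saturated ring carbon proves to be a position that moves the read-out: with the ester of compound 2 held fixed, 3,5-dichlorophenyl in place of 3-nitrophenyl gives an at least 15-fold lower number from compound 2 to compound 3 (1.19 log units; beyond the scatter). Compound 1 and compound 2 differ in more than one place and could not isolate either change, whereas this pair ties the shift to the aryl group alone, and compound 3 at 640 nM gives the series a firm number to compare against. The true size of the step stays open-ended because compound 2 is reported only as a limit: the limit of > 10000 nM in this assay, at which 1 of the 3 values shown sits.

Still open, from the compounds shown here alone, is which feature of the swap carries the step, since the nitro group leaves and two chlorine atoms enter in one move, so a single chlorine, a bromine or a trifluoromethyl group on the same phenyl ring would be needed to separate the two. Also open, going by these compounds, is whether 3,5-dichlorophenyl gives a similar step when paired with the ester of compound 1, or whether this step holds only with the ester of compound 2.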